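Inverting One Ring Stereocentre in a Kinase Inhibitor Series

This account rests on a few compounds, and the source may have more. Where it says the series, first, only, none or still open, it means among the compounds named here.

In an assay on isolated protein for inhibition of Leucine-rich repeat serine/threonine-protein kinase 2 variant G2019S (Homo sapiens), read by TR-FRET and LanthaScreen, with stated times of 50 min and 30 min, in the presence of a further agent that is not named here (on this read-out higher numbers stand for weaker inhibition and lower numbers for stronger inhibition), compound 2 `Cc1c(Nc2nc(N)c3c(C#N)c(N4CCC[C@H]4C)n(C)c3n2)cnn1[C@@H]1CCOC1` gives 12 nM, the lowest of the three numbers recorded so far. Compound 1 `Cc1nn(CC2(O)COC2)cc1Nc1nc(N)c2c(C#N)c(N3CCC[C@H]3C)n(C)c2n1` gives 51 nM in this assay, a gap beyond the usual scatter, and compound 3 `Cn1c(N2CCCC2)c(C#N)c2c(N)ncnc21` gives 1910 nM, far weaker than either. Compound 4 `Cc1c(Nc2nc(N)c3c(C#N)c(N4CCC[C@H]4C)n(C)c3n2)cnn1[C@H]1CCOC1` has not yet been tested. It differs from compound 2 in this way: the two compounds have the same atoms and bonds and differ only in configuration as drawn: 1 of 2 stereo elements differ; a stereocentre at a saturated ring carbon is drawn R in compound 2 and S in compound 4. For the measured compounds named here, no measured pair in this set shows what such an inversion does, so its direction rests on general experience rather than on these data. A modest loss is expected, with a step of a 3.3-fold higher number from compound 2 to compound 4 (0.52 log units; beyond the scatter) in this assay. Compound 4 is therefore estimated at 40 nM in this assay, within a range of 12 nM to 150 nM.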

Compound 4, half-maximal inhibitory concentration: 14 nM
Compound 4: the middle estimate sits 2.9-fold (0.46 log units) above what was measured; the measured number falls inside the stated range.
By their numbers in this assay, from the lowest: compounds 2 and 4 (each within the scatter of the next); then compound 1; then compound 3.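

In this assay, inverting the stereocentre at the saturated ring carbon gives a 1.2-fold higher number from compound 2 to compound 4 (0.07 log units; within the scatter), so this read-out does not separate the two configurations at this carbon. The earlier compounds shown here differed in more than one place and could not isolate this change, whereas this pair does: the fact that compounds 2 and 4 differ only in the configuration as drawn. On these data alone, what remains open is whether the second stereocentre tolerates inversion equally well. As far as these compounds go, it is also open whether configuration at this carbon stays as unimportant when the ring carries a larger substituent, such as an amine or a carboxylic acid.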